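The source may hold more compounds than are shown below. What is called first, only, known or untested is meant among the compounds shown, and "the series" means these compounds.

Measured in a functional assay on IMR-32 cells (Homo sapiens) for inhibition, read by sulforhodamine B assay, with a stated time of 48 h; on this read-out higher numbers stand for weaker inhibition of growth and lower numbers for stronger inhibition of growth:
Compound 1 `O=C(CCN1C(=O)CSc2ccccc21)NCCCN1CCN(c2ccc([N+](=O)[O-])cc2)CC1` gives 460 nM.
Compound 2 `COc1ccccc1N1CCN(CCCNC(=O)CCN2C(=O)CSc3ccccc32)CC1` gives > 100000 nM.

Compound 2 stands at the weak end of what has been seen, since its entry is a limit and not a number (the limit of > 100000 nM in this assay, at which 1 of the 2 values shown sits). For the measured compounds named here, the only measured step that reaches it is an at least 210-fold higher number from compound 1 to compound 2 (2.33 log units; beyond the scatter), and that step is large.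

Compound 3 `O=C(CCN1C(=O)CSc2ccccc21)NCCCN1CCN(c2ccc(C(F)(F)F)cc2)CC1` differs from compound 2 in one place: 4-(trifluoromethyl)phenyl in place of 2-methoxyphenyl on an amine nitrogen in a ring. Going by the values given here, no measured pair shows this exact exchange. The step that bears on it is an at least 210-fold higher number from compound 1 to compound 2 (2.33 log units; beyond the scatter), which concerns the same 2-methoxyphenyl that compound 3 gives up; the group entering in compound 3 is another one, so the size of the return is uncertain. A large step toward lower numbers is nonetheless expected, estimated as an at least 50-fold lower number from compound 2 to compound 3 (1.69 log units; beyond the scatter). Compound 3 is therefore expected to give about 2000 nM in this assay, within a range from 300 nM to 30000 nM.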

Compound 3, concentration for 50% growth inhibition: 1400 nM
Beside the measured number, compound 3's estimate is 1.4-fold (0.15 log units) above it, within the range that was stated.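

On the amine nitrogen in the ring, 4-(trifluoromethyl)phenyl in place of 2-methoxyphenyl gives an at least 71-fold lower number from compound 2 to compound 3 (1.85 log units; beyond the scatter), so in this assay a second group besides the 4-nitrophenyl of compound 1 brings a measured value at this position. Trifluoromethyl in place of nitro on the aromatic carbon gives a 3.0-fold higher number from compound 1 to compound 3 (0.48 log units; beyond the scatter), a modest step, so the nitro group is not needed for a measured value, although the two groups do not read the same. The larger step has no fixed size, as the entry for compound 2 is a limit and not a number: the limit of > 100000 nM in this assay, at which 1 of the 3 values shown sits.

The compounds shown leave open whether the weak reading of compound 2 follows the methoxy group itself or its place on the phenyl ring. They also do not tell how a 4-methoxyphenyl, a plain phenyl or a 4-cyanophenyl would read in this assay.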